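Adding a Methoxy Group to a Chalcone-Pyrazole Series

The source may hold more compounds than are shown below. What is called first, only, known or untested is meant among the compounds shown, and "the series" means these compounds.

Of the compounds shown here, three of this set have been tested in a functional assay on RXF 393 cells (Homo sapiens) for cytotoxicity, read by sulforhodamine B assay, with a stated time of 48 h, tested at 100 uM; on this read-out lower numbers stand for a stronger effect and higher numbers for a weaker effect at the one concentration tested. Compound 1 `COc1ccc(-c2cc(/C=C/C(=O)c3ccc(N)cc3)[nH]n2)cc1` gives -63% there. Compound 3 `COc1ccc(-c2cc(/C=C/C(=O)c3ccc(N)cc3)[nH]n2)cc1OC` gives -95%; it differs from compound 1 by methoxy in place of hydrogen on an aromatic carbon, and this change produced a number 32 percentage points lower from compound 1 to compound 3 (beyond the scatter). Compound 2 `COc1ccc(C(=O)/C=C/c2cc(-c3cc(OC)c(OC)c(OC)c3)n[nH]2)cc1OC` gives -98%; how its core differs from that of compound 1 is not broken down here. Compound 4 `COc1cc(C(=O)/C=C/c2cc(-c3cc(OC)c(OC)c(OC)c3)n[nH]2)cc(OC)c1OC` has not been measured. It differs from compound 2 by methoxy in place of hydrogen on an aromatic carbon, the same kind of change as from compound 1 to compound 3, though here the place is also meta to a methoxy group. Because compound 2 already gives -98%, little further lowering seems possible, so the expected step is a number 1 percentage points higher from compound 2 to compound 4 (within the scatter). Compound 4 is therefore estimated at -97%, between -100% and -85%.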

Compound 4, a percentage reported as activity, at one concentration (the size of the read-out at that concentration, not a potency): -98%
Estimate against measurement, compound 4: 1 percentage points above; measured number inside the range.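

In this assay, adding a methoxy group on the second core gave no change at the digits printed from compound 2 to compound 4 (within the scatter), so the size of the step did not carry over from one core to the other: the same change on two cores in this assay, a number 32 percentage points lower (beyond the scatter) from compound 1 to compound 3 and no change at the digits printed (within the scatter) from compound 2 to compound 4, 32 percentage points apart, beyond the scatter of two such steps. This shows that the large step seen on the core of compound 1 cannot be assumed to appear on another core in this series. It does not show why the two steps differ, and two cores, tested in one cell line at one concentration, are too few to give a general rule or to say more than whether the effect at that concentration is stronger or weaker.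

The compounds shown leave open what a hydroxyl group or a longer chain such as ethoxy would do in place of the added methoxy on either core.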